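This account rests on a few compounds, and the source may have more. Where it says the series, first, only, none or still open, it means among the compounds named here.

The measured compounds:
Compound 1, `COc1cccc(CN2C(=O)CN(C(=O)c3cc4cc(OC)ccc4o3)C[C@@H]2CCc2ccccc2)c1`, in an ADME assay on microsomes from liver (Homo sapiens) for metabolic stability, with a stated time of 30 min, tested at 1 uM (on this read-out higher numbers stand for a longer-lived compound and lower numbers for a shorter-lived compound), gives 0.128 h.
Compound 2, `COc1ccc2[nH]c(C(=O)N3CC(=O)N(Cc4ccccc4)[C@@H](COc4ccccc4)C3)cc2c1`, in this assay gives 0.65 h.
Compound 3, `COc1ccc2[nH]c(C(=O)N3CC(=O)N(Cc4ccccc4)[C@@H](COC(C)(C)C)C3)cc2c1`, in this assay gives 0.278 h.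

Compound 3 stands second highest of the three numbers. Its nearest neighbour is compound 1, below it beyond the scatter, and its furthest is compound 2, above it beyond the scatter. Compound 4, `COc1ccc2[nH]c(C(=O)N3CC(=O)N(Cc4ccccc4)[C@@H](COc4ccc(F)cc4)C3)cc2c1`, has not yet been measured. It differs from compound 3 in one place: 4-fluorophenyl in place of tert-butyl on an oxygen on a saturated carbon. A single measured step bears on this change, a 2.3-fold lower number from compound 2 to compound 3 (0.37 log units; beyond the scatter), in which a phenyl on the same oxygen was exchanged for tert-butyl. Compound 4 largely reverses that exchange, returning an aromatic ring to the oxygen, now carrying a fluorine. The expected step in this assay is therefore a rise, a 2.5-fold higher number from compound 3 to compound 4 (0.40 log units; beyond the scatter), mirroring the measured drop in reverse. Compound 4 is accordingly estimated at 0.7 h, with a range from 0.35 h to 1.4 h.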

Compound 4, half-life: 0.317 h
The estimate for compound 4 lay 2.2-fold (0.34 log units) above the measured number; the whole stated range lies above it.
By their numbers in this assay, from the lowest: compound 1; then compounds 3 and 4 (each within the scatter of the next); then compound 2.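

In this assay the exchange of tert-butyl for 4-fluorophenyl on the oxygen gives a 1.1-fold higher number from compound 3 to compound 4 (0.06 log units; within the scatter) and so separates the two groups by no more than repeat measurements would. Fluoro in place of hydrogen on the aromatic ring, by contrast, gives a 2.1-fold lower number from compound 2 to compound 4 (0.31 log units; beyond the scatter) and is the only change in this series that separates the two aromatic groups. At this position, then, the higher number of compound 2 does not extend to every aromatic ring on the oxygen, since it is lost with this single fluorine among the compounds shown.

Nothing available accounts for the effect of the fluorine on the half-life. From the compounds shown here alone, it remains open how a chloro or methoxy group on the same phenyl ring, or an amine on a chain in place of the ring, would compare.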